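Dropping the Amide Methyl: From Compound 3 to Compound 4

This account rests on a few compounds, and the source may have more. Where it says the series, first, only, none or still open, it means among the compounds named here.

Compound 3 `CNC(=O)CN1CCC(c2ccc(Nc3ncc4ccc(-c5ccccc5OC)n4n3)c(OC)c2)CC1` was tested in an in vitro ADME assay on microsomes from liver (Macaca mulatta) for metabolic stability, using NADPH, with a stated time of 10 min, tested at 0.5 uM; a higher number here means that the compound lasts longer, a lower number that the compound disappears faster. In this assay compound 3 gives < 0.2 h, which is a limit of the assay and not a number (the limit of < 0.2 h in this assay, at which 1 of the 3 values shown sits). Compound 1 `COc1cc(C2CCNCC2)ccc1Nc1ncc2ccc(-c3ccccc3N(C)S(C)(=O)=O)n2n1` gives < 0.0834 h, likewise a limit (the limit of < 0.0834 h in this assay, at which 1 of the 3 values shown sits). Among the measured compounds shown here, compound 2 `COc1cc(C2CCN(C[C@@H](C)O)CC2)ccc1Nc1ncc2ccc(-c3ccccc3OC)n2n1` gives 0.35 h, the only one of the three values that is a number. For the measured compounds named here, the only measured step that touches compound 3 is an at least 1.7-fold lower number from compound 2 to compound 3 (0.24 log units; that floor lies within the scatter), and since compound 3 is a limit, that step sets only a floor, one that lies within the scatter.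

Compound 4 `COc1cc(C2CCN(CC(N)=O)CC2)ccc1Nc1ncc2ccc(-c3ccccc3OC)n2n1` differs from compound 3 by hydrogen in place of methyl on an amide-type nitrogen, a hydrogen in place of methyl on an amide-type nitrogen. Going by the values given here, no measured pair in this set shows that change, so the one step that bears on it is the floor from compound 2 to compound 3, and it says nothing about direction. Compound 4 is therefore expected to move no further than the scatter from compound 3, as the estimated step that the limit leaves unreadable from compound 3 to compound 4. For compound 4 the expected value in this assay is 0.15 h, within a range of 0.06 h to 0.4 h, and it is expected that the assay again reports a limit rather than a number.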

Compound 4, half-life: > 0.666 h
Compound 4 ended at the assay's limit (the forecaster's own chance of this, stated with the estimate: 60%); middle value at least 4.4-fold (0.64 log units) away from the limit.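

Read between two limits of the assay, hydrogen in place of methyl on the amide-type nitrogen gives an at least 3.3-fold higher number from compound 3 to compound 4 (0.52 log units; beyond the scatter), the first step at this position in this assay that clears the scatter, and it comes from the loss of a single methyl. Compound 4 stands at a limit of the assay and not at a number: the limit of > 0.666 h in this assay, at which 1 of the 4 values shown sits. Carbamoyl in place of 1-hydroxyethyl gives an at least 1.9-fold higher number from compound 2 to compound 4 (0.27 log units; that floor lies within the scatter), a floor that does not yet separate the two compounds, so compound 2 and compound 4 cannot be put in order.

The compounds shown leave open how far past its limit compound 4 lies, and so the full size of both steps, as well as whether the same change from methyl to hydrogen would carry the same weight with other groups on the shared core. They also leave open how an ethyl on the amide-type nitrogen, or a carboxylic acid in place of the carbamoyl group, would stand in this assay.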